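Replacing dimethylcarbamoyl with bromo in the series

The source may hold more compounds than are shown below. What is called first, only, known or untested is meant among the compounds shown, and "the series" means these compounds.

Measured in a functional assay on HeLa cells (Homo sapiens) for antiproliferative activity, read by CCK-8 assay, with a stated time of 72 h; on this read-out higher numbers stand for weaker inhibition and lower numbers for stronger inhibition:
compound 1 `COc1cc(-c2ncncc2-c2ccc(OCC(F)(F)F)cc2)cc(OC)c1OC` gives 10200 nM as its value
compound 2 `COc1cc(-c2ncncc2-c2ccc(C(N)=O)cc2)cc(OC)c1OC` gives > 100000 nM which is a limit of the assay and not a number
compound 3 `COc1cc(-c2ncncc2-c2ccc(C(=O)N(C)C)cc2)cc(OC)c1OC` gives 790 nM as its value

Among the compounds with values here, compound 3 stands lowest of the numbers, with 790 nM as the best value so far. Compound 4 `COc1cc(-c2ncncc2-c2ccc(Br)cc2)cc(OC)c1OC` has bromo in place of dimethylcarbamoyl on an aromatic carbon and is still unmeasured. The nearest guide is a 13-fold lower number from compound 1 to compound 3 (1.11 log units; beyond the scatter) in this series. Compound 1 also lacks a carbamoyl group. The step of an at least 120-fold lower number from compound 2 to compound 3 (2.10 log units; beyond the scatter) shows that the dimethylcarbamoyl outperforms the plain carbamoyl. Losing dimethylcarbamoyl should therefore raise the number. The step expected in this assay is a 5.1-fold higher number from compound 3 to compound 4 (0.70 log units; beyond the scatter) toward weaker inhibition, beyond the scatter. Compound 4 is estimated at 4000 nM within 900 nM to 20000 nM for now.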

Compound 4, half-maximal inhibitory concentration: 500 nM
For compound 4 the middle estimate is 8.0-fold (0.90 log units) above the measured one; the measured number lies below the stated range.
By their numbers in this assay, from the lowest: compounds 4 and 3 (each within the scatter of the next); then compound 1. At a limit, above all of these: compound 2.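

In this assay the dimethylcarbamoyl on this aromatic carbon, para to a large group, is no requirement: bromo gives a 1.6-fold lower number from compound 3 to compound 4 (0.20 log units; within the scatter) and carries no carbonyl. Against 2,2,2-trifluoroethoxy, bromo gives a 20-fold lower number from compound 1 to compound 4 (1.31 log units; beyond the scatter) and so a carbonyl is not what separates the better compounds from compound 1. The step against carbamoyl, an at least 200-fold lower number from compound 2 to compound 4 (2.30 log units; beyond the scatter), starts from a limit of the assay and not a number: the limit of > 100000 nM in this assay, at which 1 of the 4 values shown sits.

Open, going by these compounds, is how chloro, methyl or a primary amine would read at this position. Also open, on these data alone, is whether bromo and dimethylcarbamoyl land together for one shared reason or for separate ones.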